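A few compounds are considered here, and "the series" means these few. Any claim that something is new, unique, unknown or untested is made for them only; others in the source may bear on it.

In a functional assay on MDA-MB-231 cells (Homo sapiens) for antiproliferative activity, read by MTT assay, with a stated time of 24 h (on this read-out higher numbers stand for weaker inhibition and lower numbers for stronger inhibition), compound 3, whose structure is `COc1ccc(C(=O)/C=C/c2cc(-c3cc(OC)c(OC)c(OC)c3)n3nc(-c4ccccc4)cc3n2)cc1OC`, gives 18300 nM. Among the three measured compounds this is the second highest number: compound 2, `COc1cc(/C=C/C(=O)c2cc(-c3cc(OC)c(OC)c(OC)c3)n3nc(-c4ccccc4)cc3n2)cc(OC)c1OC`, gives 18400 nM, which lies within the scatter of compound 3, while compound 1, `COc1ccc(-c2cc(/C=C/C(=O)c3cc(OC)c(OC)c(OC)c3)nc3cc(-c4ccccc4)nn23)cc1OC`, gives 4700 nM, the lowest of the three and well apart from compound 3.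

Compound 4, `COc1ccc(C(=O)/C=C/c2cc(-c3ccc(OC)c(OC)c3)n3nc(-c4ccccc4)cc3n2)cc1OC`, differs from compound 3 by hydrogen in place of methoxy on an aromatic carbon. Among the measured compounds shown here, no pair of measured compounds shows this change on its own, so its effect here is unknown. The step is expected to be small, not beyond the usual scatter, in either direction. Compound 4 is therefore estimated at 16000 nM, with a range from 5000 nM to 50000 nM, which means an expected step of a 1.1-fold lower number from compound 3 to compound 4 (0.06 log units; within the scatter).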

Compound 4, half-maximal inhibitory concentration: 2600 nM
Compound 4: middle estimate off by 6.2-fold (0.79 log units), on the high side, outside the stated range (below it).
By their numbers in this assay, from the lowest: compounds 4 and 1 (each within the scatter of the next); then compounds 3 and 2 (each within the scatter of the next).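

In this assay, trimming 3,4,5-trimethoxyphenyl to 3,4-dimethoxyphenyl gives a 7.0-fold lower number from compound 3 to compound 4 (0.85 log units; beyond the scatter), so the number at this position does respond to losing one methoxy group. The same change made at a different place gives a 1.8-fold lower number from compound 1 to compound 4 (0.26 log units; within the scatter), which stays within the scatter, so in these compounds its size depends on where it is made. Nothing measured here accounts for this difference.

Hydrogen is the only replacement for methoxy shown at this position. From the compounds shown here alone, how a hydroxy group, a fluorine atom or an ethoxy group would behave there remains open.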